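Shifting the halogen on the pendant phenyl: compound 3 to 4

The compounds below may be only part of what the source reports. "The series", "measured", "known", "first", "only" and "open" are said of these compounds alone.

The measured compounds and their numbers:
Compound 1 `O=S(=O)(c1ccc(F)c(F)c1)c1cnc2c(F)cccc2c1-c1cccc(F)c1` in an ADME assay on microsomes from liver (Homo sapiens) for metabolic stability, tested at 2.5 uM; a higher number here means faster removal of the compound, a lower number slower removal: 1.28 mL/min
Compound 2 `N#Cc1cccc(S(=O)(=O)c2cnc3c(F)cccc3c2-c2cccc(Cl)c2)c1` in this assay: 1.11 mL/min
Compound 3 `N#Cc1cccc(S(=O)(=O)c2cnc3c(F)cccc3c2-c2ccc(Cl)cc2)c1` in this assay: 0.08 mL/min

Compound 3 stands at the bottom of the three numbers. Its nearest neighbour is compound 2, which shows a markedly higher number, and compound 1 lies still further up. For the measured compounds named here, the one single-point step among the measured compounds is a 14-fold lower number from compound 2 to compound 3 (1.14 log units; beyond the scatter), and it is this step that bears most directly on the move now considered.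

Compound 4 `N#Cc1cccc(S(=O)(=O)c2cnc3c(F)cccc3c2-c2cccc(F)c2)c1` differs from compound 3 in one place: 3-fluorophenyl in place of 4-chlorophenyl on an aromatic carbon. The change puts the halogen back into the position it occupies in compound 2, while also swapping chlorine for fluorine. Going by the values given here, compound 1 carries the same 3-fluorophenyl group on the shared core and gives a high number, though its sulfonyl aryl differs, so no step for that pair is counted here.

Given the large step from compound 2 to compound 3, the expectation is that compound 4 climbs back toward the level of compound 2, an expected step of an 11-fold higher number from compound 3 to compound 4 (1.05 log units; beyond the scatter). Compound 4 is therefore estimated at 0.9 mL/min in this assay, with a range from 0.3 mL/min to 2 mL/min.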

Compound 4, intrinsic clearance in a liver preparation (reported as CLH), per the amount of preparation that the assay uses: 0.34 mL/min
Estimate against measurement, compound 4: 2.6-fold (0.42 log units) above; measured number inside the range.
By their numbers in this assay, from the lowest: compound 3; then compound 4; then compounds 2 and 1 (each within the scatter of the next).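

In this assay the return of the halogen to the place it holds in compound 2 brings a 4.3-fold higher number from compound 3 to compound 4 (0.63 log units; beyond the scatter) and stops short of the level of compound 2, which shows that the place of the halogen on the pendant phenyl is not the only thing that sets the number. For the compounds shown here, with that place held fixed, the halogen itself counts: fluoro in place of chloro gives a 3.3-fold lower number from compound 2 to compound 4 (0.51 log units; beyond the scatter) and this is the first reading of that exchange on the shared core. With 3-fluorophenyl held constant, the group on the sulfonyl sulfur also proves able to move the number, as 3-cyanophenyl in place of 3,4-difluorophenyl gives a 3.8-fold lower number from compound 1 to compound 4 (0.58 log units; beyond the scatter) and the series thus responds at both ends of the shared core.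

The compounds shown leave open how 4-fluorophenyl would read, which would complete the pairing of the two halogens with the two places, and whether an amine or a methoxy group on the pendant phenyl would be tolerated at the low end of these numbers. Nothing at hand explains why the numbers shift with these changes.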